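From compound 2 to compound 3: one side chain exchanged

The source may hold more compounds than are shown below. What is called first, only, known or untested is meant among the compounds shown, and "the series" means these compounds.

Compound 1 `COc1ccc(C(=O)N(Cc2ccncc2)Cc2cccc(OCC3CCOCC3)c2)cc1`: 17700 nM
Compound 2 `COc1ccc(C(=O)N(Cc2ccncc2)Cc2cccc(OCCc3ccc(Br)cc3)c2)cc1`: 8400 nM

Both values come from a functional assay on KMS-11 cells (Homo sapiens) for antiproliferative activity, read by CellTiter-Glo, with a stated time of 72 h; on this read-out lower numbers stand for stronger inhibition and higher numbers for weaker inhibition. Going by the values given here, of the two compounds measured so far, compound 2 stands lowest at 8400 nM. The next compound is compound 3 `COc1ccc(C(=O)N(Cc2ccncc2)Cc2cccc(OCc3cccc([N+](=O)[O-])c3)c2)cc1`, which keeps the shared core and changes one group: 3-nitrophenyl in place of 4-bromobenzyl on a saturated chain carbon bound to an oxygen on an aromatic ring. Cut one bond further out, the same difference reads 2-(4-bromophenyl)ethyl to 3-nitrobenzyl.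

Among the compounds with values here, only one measured step bears on this change: a 2.1-fold lower number from compound 1 to compound 2 (0.32 log units; beyond the scatter). It concerns the same place, on a saturated chain carbon bound to an oxygen on an aromatic ring, but involves a different pair of groups, so it gives only a rough guide to size and none to direction. On that evidence, a small step is expected in this assay, probably not beyond the scatter, and the data fix no direction for it. The step expected is a 1.2-fold higher number from compound 2 to compound 3 (0.08 log units; within the scatter). For compound 3 the estimated value is 10000 nM, with an expected range of 4000 nM to 25000 nM.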

Compound 3, half-maximal inhibitory concentration: 19600 nM
Compound 3: middle estimate off by 2.0-fold (0.29 log units), on the low side, within the range that was stated.
By their numbers in this assay, from the lowest: compound 2; then compounds 1 and 3 (each within the scatter of the next).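

In this assay, the place on a saturated chain carbon bound to an oxygen on an aromatic ring now shows a step in both directions: after a 2.1-fold lower number from compound 1 to compound 2 (0.32 log units; beyond the scatter) comes a 2.3-fold higher number from compound 2 to compound 3 (0.37 log units; beyond the scatter), so replacing 4-bromobenzyl with 3-nitrophenyl gives up the modest gain. Compound 1 and compound 3 cannot be told apart, with a 1.1-fold higher number from compound 1 to compound 3 (0.04 log units; within the scatter), so among these three compounds only the 2-(4-bromophenyl)ethyl side chain of compound 2 stands apart, and only by a modest margin. Nothing measured here accounts for this difference.

The step from compound 2 to compound 3 changes the chain length, the substituent and its ring position at once, so the compounds shown cannot say which of these matters, and a 2-(3-nitrophenyl)ethyl or a 3-bromobenzyl side chain would separate them. As far as these compounds go, it also remains open whether this place tolerates anything quite different, such as an amine or a carboxylic acid on the benzyl ring, and whether any group here can move the values by more than these modest steps.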